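Furan to thiophene at the aryl position of compound 2

The source may report more compounds than this note shows. Statements on the series, on what has been measured and on what is new or still open speak of the compounds shown alone.

Among the two measured compounds, compound 2 `c1ccc(-c2ccoc2)c(OCC2=NCCN2)c1` gives the lower number: in a functional assay for activation of Alpha-1B adrenergic receptor (Homo sapiens), read by calcium flux (a lower number here means that less compound is needed, a higher number that more compound is needed for the effect), compound 2 gives 5.01 nM, while compound 1 `c1ccc(-c2cnccn2)c(OCC2=NCCN2)c1` gives 631 nM. For the measured compounds named here, the only measured step, a 130-fold lower number from compound 1 to compound 2 (2.10 log units; beyond the scatter), shows how strongly this assay responds to the group on that aromatic carbon. Compound 3 `c1ccc(-c2ccsc2)c(OCC2=NCCN2)c1` differs from compound 2 by thiophen-3-yl in place of furan-3-yl on an aromatic carbon. Going by the values given here, no measured step covers a furan-to-thiophene exchange, so the large step from compound 1 to compound 2 bears on the expectation only by marking the position as sensitive. A five-membered ring with one hetero atom remains in place, so compound 3 is expected to stay close to compound 2, with a 1.6-fold higher number from compound 2 to compound 3 (0.20 log units; within the scatter) as the estimated step. Compound 3 is therefore estimated at 8 nM, within a range of 2 nM to 40 nM.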

Compound 3, half-maximal effective concentration: 15.9 nM
Beside the measured number, compound 3's estimate is 2.0-fold (0.30 log units) below it, within the range that was stated.
By their numbers in this assay, from the lowest: compound 2; then compound 3; then compound 1.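

In (this assay), furan-3-yl and thiophen-3-yl are both five-membered aromatic rings with 1 hetero atom, yet the exchange of oxygen for sulfur on this aromatic carbon gives (a 3.2-fold higher number from compound 2 to compound 3 (0.50 log units; beyond the scatter)), so the position separates even these two closely matched groups. Thiophen-3-yl still retains most of the gain over pyrazin-2-yl, with (a 40-fold lower number from compound 1 to compound 3 (1.60 log units; beyond the scatter)), which places the two five-membered rings far closer to each other than to the pyrazin-2-yl compound. The information at hand offers no explanation for either step.

On these data alone, it remains open how an unsubstituted phenyl, a pyrrol-3-yl or a thiazolyl ring would behave on the same aromatic carbon. As far as these compounds go, it is also open whether thiophen-2-yl or furan-2-yl would follow the order seen for the groups attached through their 3-positions.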